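The source may report more compounds than this note shows. Statements on the series, on what has been measured and on what is new or still open speak of the compounds shown alone.

In an ADME assay on L02 cells (Homo sapiens) for cytotoxicity, read by MTT assay, with a stated time of 24 h (on this read-out lower numbers stand for stronger inhibition and higher numbers for weaker inhibition), compound 1 (`CN1C/C(=C\c2ccc(C(F)(F)F)cc2)C(=O)/C(=C/c2cccnc2)C1`) gives 15600 nM and compound 2 (`CN1C/C(=C\c2ccncc2)C(=O)/C(=C/c2ccc(C(F)(F)F)cc2)C1`) gives 17400 nM on the same read-out. Compound 3 (`O=C1/C(=C/c2cccnc2)CN(S(=O)(=O)c2ccccc2)C/C1=C\c1ccccc1F`) gives 15300 nM and so stands within the scatter of both, with nothing to set it apart from them.

Compound 4 (`CC(=O)Nc1ccc(S(=O)(=O)N2C/C(=C\c3cccnc3)C(=O)/C(=C/c3ccccc3F)C2)cc1`) differs from compound 3 in one place, where phenyl becomes 4-acetamidophenyl (acetamido in place of hydrogen on an aromatic carbon) and acetamido takes the place of hydrogen on an aromatic carbon, para to a large group.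

For the measured compounds named here, no measured pair tests this change directly. Going by the values given here, the only measured step between compounds that differ in one place is a 1.1-fold higher number from compound 1 to compound 2 (0.05 log units; within the scatter) and it lies within the scatter, but it concerns pyridin-4-yl in place of pyridin-3-yl and not acetamido. It therefore bears on the change only loosely. Some further support comes from compound 1 at 15600 nM and compound 3 at 15300 nM since these two values lie within the scatter although the structures differ in more than one place. No step beyond the scatter is therefore expected in this assay and neither direction is favoured.

For compound 4 the expected step is a 1.0-fold lower number from compound 3 to compound 4 (0.01 log units; within the scatter) and it stays within the scatter. For compound 4 the estimated value is 15000 nM with an expected range from 6500 nM to 35000 nM on this reading.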

Compound 4, half-maximal inhibitory concentration: 15600 nM
Estimate against measurement, compound 4: 1.0-fold (0.02 log units) below, within the range that was stated.
By their numbers in this assay, from the lowest: compounds 3, 1, 4 and 2 (each within the scatter of the next).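

In this assay, acetamido in place of hydrogen on an aromatic carbon, para to a large group, gives a 1.0-fold higher number from compound 3 to compound 4 (0.01 log units; within the scatter), so this substitution stays within the scatter. For the compounds shown here, until now, the only one-place step concerned pyridin-4-yl in place of pyridin-3-yl, and the looser agreement among the other values said nothing about this position; this pair shows directly that phenyl can become 4-acetamidophenyl, with its added hydrogen-bond donor and acceptor, without a step beyond the scatter on this read-out. Nothing available explains why the two numbers stay so close, and the result is recorded here as an observation alone.

The compounds shown put only hydrogen and acetamido at this position, so it remains open whether an amine, a carboxylic acid or a longer chain there would stay within the scatter or move the number beyond it. The finding also rests on a single pair sharing one core, which leaves open whether acetamido would give the same result on the core of compound 1 or of compound 2.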